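The source may report more compounds than this note shows. Statements on the series, on what has been measured and on what is new or still open speak of the compounds shown alone.

Compound 3 `NC(=O)c1ccccc1C(=O)N1CCC(N(C2CC2)S(=O)(=O)c2cccc(C(F)(F)F)c2)CC1`: 17%
Compound 1 `COC(=O)c1cccc(C(=O)N2CCC(N(C3CC3)S(=O)(=O)c3cccc(C(F)(F)F)c3)CC2)c1`: "not determined" (no result reported)
Compound 2 `O=C(c1ccccc1)N1CCC(N(C2CC2)S(=O)(=O)c2cccc(C(F)(F)F)c2)CC1`: "not determined" (no result reported)

In an assay on cells for inhibition of Voltage-dependent L-type calcium channel subunit alpha-1C (Homo sapiens), read by FLIPR and calcium flux, tested at 3 uM (on this read-out lower numbers stand for a weaker effect and higher numbers for a stronger effect at the one concentration tested), compound 3 gives 17%. Among the compounds with values here, this is the only number in the set: compound 1 gives "not determined" (no result reported) and compound 2 gives "not determined" (no result reported) in this assay, both sharing the same sulfonamide-piperidine core but carrying no reported result, so compound 3 stands alone, and nothing can be said about where it ranks among its neighbours. The value itself marks a modest effect at the single concentration tested.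

Compound 4 `O=C(c1ccc(OC(F)(F)F)cc1)N1CCC(N(C2CC2)S(=O)(=O)c2cccc(C(F)(F)F)c2)CC1` is the next compound to be measured. It differs from compound 3 in one place: 4-(trifluoromethoxy)phenyl in place of 2-carbamoylphenyl on a carbonyl carbon.

Within the data shown here, with no pair of measured compounds available to show how a change on this carbonyl carbon shifts the read-out, the size and direction of the step in this assay cannot be taken from the data. The expectation is therefore a cautious one: a step that may well stay within the usual scatter, with the chance of a somewhat larger movement in either direction left open. On that basis compound 4 is expected to give about 25%, with a plausible range from 5% to 55%. The step from compound 3 to compound 4 that this estimate means is a number 8 percentage points higher from compound 3 to compound 4 (within the scatter), and it is given as an expectation only.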

Compound 4, a percentage reported as inhibition, at one concentration (the size of the read-out at that concentration, not a potency): 88%
Compound 4: middle estimate off by 63 percentage points, on the low side, and the stated range ends below it.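

In this assay, the group on the carbonyl carbon turns out to matter a great deal: with the rest of the molecule unchanged, putting 4-(trifluoromethoxy)phenyl in place of 2-carbamoylphenyl gives a number 71 percentage points higher from compound 3 to compound 4 (beyond the scatter). Within the data shown here, this is the first measured sign that the read-out responds to a change at this place, which a single value could not show. The two groups differ in several ways at once, since the hydrogen-bond donor and the nitrogen leave while fluorine enters, and nothing measured here ties the step to any one of these differences or gives a reason for it.

Steps involving compound 1 or compound 2 cannot be read, so the plain phenyl of compound 2 offers no measured midpoint between the two groups, and it stays open whether losing the 2-carbamoyl group or gaining the 4-(trifluoromethoxy) group accounts for more of the change. The compounds shown also leave open how the read-out would respond to a 4-methoxyphenyl group or a carboxylic acid on the ring, or to any change elsewhere on the shared core.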